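Ester variation: difluorobenzyl to (furan-2-yl)methyl

The compounds below may be only part of what the source reports. "The series", "measured", "known", "first", "only" and "open" are said of these compounds alone.

Measured in a functional assay on HEK293 cells for antagonist activity at Voltage-dependent L-type calcium channel subunit alpha-1C (Oryctolagus cuniculus), read by FLIPR; on this read-out higher numbers stand for weaker inhibition and lower numbers for stronger inhibition:
compound 1 `C=CCOC(=O)C1=C(C)NC(C)=C(C(=O)OC)C1c1cccc([N+](=O)[O-])c1`: 15 nM
compound 2 `C#CCCOC(=O)C1=C(C)NC(C)=C(C(=O)OC)C1c1cccc([N+](=O)[O-])c1`: 31 nM
compound 3 `COC(=O)C1=C(C)NC(C)=C(C(=O)OCc2ccc(F)c(F)c2)C1c1cccc([N+](=O)[O-])c1`: 7 nM

Compound 3 gives the lowest number of the three: a 2.1-fold lower number from compound 1 to compound 3 (0.33 log units; beyond the scatter) and a 4.4-fold lower number from compound 2 to compound 3 (0.65 log units; beyond the scatter). Among the open-chain esters, a 2.1-fold higher number from compound 1 to compound 2 (0.32 log units; beyond the scatter).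

Compound 4 `COC(=O)C1=C(C)NC(C)=C(C(=O)OCc2ccco2)C1c1cccc([N+](=O)[O-])c1` differs from compound 3 by furan-2-yl in place of 3,4-difluorophenyl on a saturated chain carbon bound to an oxygen next to a carbonyl group. Going by the values given here, all three measured steps vary this same ester position, and each was modest; none exchanges one aromatic ring for another, so no measured step bears directly on this change. The expectation is therefore a step no larger than those seen, most likely a modest move upward from compound 3. Compound 4 is expected at 11 nM (range 4 nM to 28 nM), which is an estimated 1.6-fold higher number from compound 3 to compound 4 (0.20 log units; within the scatter).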

Compound 4, half-maximal inhibitory concentration: 20 nM
Estimate against measurement, compound 4: 1.8-fold (0.26 log units) below; low and high end bracket the measured number.
By their numbers in this assay, from the lowest: compound 3; then compounds 1, 4 and 2 (each within the scatter of the next, the first and the last beyond it).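

In this assay, an aromatic ring at this position does not by itself keep the low number of compound 3: a 2.9-fold higher number from compound 3 to compound 4 (0.46 log units; beyond the scatter) for the change to furan-2-yl. The furan-2-yl ester also stays level with both open-chain esters, with a 1.6-fold lower number from compound 2 to compound 4 (0.19 log units; within the scatter) and a 1.3-fold higher number from compound 1 to compound 4 (0.12 log units; within the scatter), so among these compounds only the 3,4-difluorophenyl group stands apart. Nothing at hand accounts for this difference.

The compounds shown leave open whether the two fluorines or the ring type carries the step from compound 3 to compound 4. An unsubstituted benzyl ester at the same place would separate the two.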